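The source may hold more compounds than are shown below. What is called first, only, known or untested is meant among the compounds shown, and "the series" means these compounds.

Of the compounds shown here, two have been measured in an assay on CHO cells for agonist activity at Glucose-dependent insulinotropic receptor (Homo sapiens), read by a luciferase reporter and cAMP accumulation, with a stated time of 2 h; on this read-out higher numbers stand for an effect only at larger amounts of compound and lower numbers for an effect already at smaller amounts. Compound 1 `CC(C)SC(=O)N1CCC(Oc2cc(N3CCc4ccccc43)ncn2)CC1` gives > 10000 nM, which is a limit of this assay and not a number. Among the compounds with values here, compound 2 `CC(C)c1noc(N2CCC(Oc3cc(N4CCc5cc([S+]([O-])CCO)ccc54)ncn3)CC2)n1` gives 48 nM in this assay, the only number in the set. The other value, that of compound 1, is a limit of this assay (the limit of > 10000 nM in this assay, at which 1 of the 2 values shown sits). Compound 3 `CC(C)c1noc(N2CCC(Oc3cc(N4CCc5cc(N6CCOCC6=O)ccc54)ncn3)CC2)n1` has not yet been measured in this assay. It differs from compound 2 in one place a group of 7 heavy atoms (4 carbon, 1 nitrogen, 2 oxygen; one six-membered non-aromatic ring with 2 hetero atoms) in place of a group of 5 heavy atoms (2 carbon, 2 oxygen, 1 sulfur; no ring), on an aromatic carbon: a 3-oxomorpholin-4-yl group, one six-membered non-aromatic ring with 2 hetero atoms, sits on an aromatic carbon of a six-membered aromatic ring of carbon only, part of a fused system of two rings, where compound 2 carries a group of 5 heavy atoms with no ring. No step between measured compounds is shown, so the data give no guide to how such an exchange moves the numbers. The step is expected to stay within the usual scatter a 1.2-fold lower number from compound 2 to compound 3 (0.08 log units; within the scatter). Compound 3 is expected to give 40 nM in this assay, between 12 nM and 130 nM.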

Compound 3, half-maximal effective concentration: 15 nM
Estimate against measurement, compound 3: 2.7-fold (0.43 log units) above; measured number inside the range.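

In this assay, placing a 3-oxomorpholin-4-yl group on this aromatic carbon, in place of the open group with no ring, gives a 3.2-fold lower number from compound 2 to compound 3 (0.51 log units; beyond the scatter). Within the data shown here, this is the first step that can be read at this position, and it shows that the place accepts a group with one six-membered non-aromatic ring and 0 hydrogen-bond donors without any rise in the number. Nothing among the data shown bears on the reason for this step.

The two groups differ in several features at once, so the compounds shown leave open whether the ring, the carbonyl or the loss of the hydrogen-bond donor goes with the lower number. They also leave open how a plain morpholin-4-yl group, a carboxylic acid or a longer chain would behave on this same aromatic carbon.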